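Swapping Chloro for Nitro on a Chalcone Lactam

The compounds below may be only part of what the source reports. "The series", "measured", "known", "first", "only" and "open" are said of these compounds alone.

Among the compounds with values here, compound 1 `O=C(COc1ccc(C(=O)/C=C/c2cccc(Cl)c2)cc1)N[C@H]1CCOC1=O` is the only compound with a numerical reading in a functional assay on PC-3 cells (Homo sapiens) for antiproliferative activity, read by MTT assay, with a stated time of 72 h (a lower number here means a stronger inhibitor, a higher number a weaker inhibitor), where compound 1 gives 4990 nM. Compound 2 `O=C(CNc1ccc(Br)cc1)N[C@H]1CCOC1=O` reaches only a limit in this assay, reported as > 64000 nM. Compound 3 `O=C(COc1ccc(C(=O)/C=C/c2cccc([N+](=O)[O-])c2)cc1)N[C@H]1CCOC1=O` has not yet been measured; it differs from compound 1 by nitro in place of chloro on an aromatic carbon. Within the data shown here, no measured pair differing in a single place exists here, so the size of the step in this assay has no precedent; a change of this kind is expected to stay within the usual scatter, in either direction. Compound 3 is accordingly estimated at 4000 nM, with a range from 1500 nM to 13000 nM. The expected step is a 1.2-fold lower number from compound 1 to compound 3 (0.10 log units; within the scatter).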

Compound 3, half-maximal inhibitory concentration: 56300 nM
For compound 3 the middle estimate is 14-fold (1.15 log units) below the measured one; measured number outside the range, above it.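

Within the data shown here, at this position, on an aromatic carbon meta to a large group, nitro in place of chloro is the first single change that can be read in this assay, and it gives an 11-fold higher number from compound 1 to compound 3 (1.05 log units; beyond the scatter). The position is therefore not indifferent to what sits there. Compound 2 gives only a limit, and the new reading comes close to it: the limit of > 64000 nM in this assay, at which 1 of the 3 values shown sits.

On these data alone, whether an amine, a methoxy group or a carboxylic acid at this position would keep the activity of compound 1 remains open. So does the question of whether any other position on this ring responds as strongly.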